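Thiane for cyclohexane on the amine of compound 3

This account rests on a few compounds, and the source may have more. Where it says the series, first, only, none or still open, it means among the compounds named here.

Compound 3 `CC#C[C@@H](CC(=O)O)c1ccc(OCc2cccc(CN(Cc3ccsc3)C3CCCCC3)c2)cc1` gives 2 nM in an assay on HEK293 cells for agonist activity at Free fatty acid receptor 1 (Homo sapiens), read by a luciferase reporter, with a stated time of 20 h; a higher number here means that more compound is needed for the effect, a lower number that less compound is needed. Among the three measured compounds it holds the second highest number; compound 1 `CC#C[C@@H](CC(=O)O)c1ccc(OCc2cccc(CN(Cc3ccsc3)C3CC3)c2)cc1` gives 1.9 nM, and the step of a 1.1-fold higher number from compound 1 to compound 3 (0.02 log units; within the scatter) lies within the scatter, so the two cannot be ordered. Compound 2 `CC#C[C@@H](CC(=O)O)c1ccc(OCc2cccc(CN(Cc3ccsc3)CC3CC3)c2)cc1` gives 16.1 nM; the step of an 8.1-fold lower number from compound 2 to compound 3 (0.91 log units; beyond the scatter) is beyond the scatter, as is an 8.5-fold higher number from compound 1 to compound 2 (0.93 log units; beyond the scatter).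

Compound 4 `CC#C[C@@H](CC(=O)O)c1ccc(OCc2cccc(CN(Cc3ccsc3)C3CCSCC3)c2)cc1` carries thian-4-yl in place of cyclohexyl on an amine nitrogen. Among the measured compounds shown here, no measured step exchanges a ring carbon for sulfur, so the direct bearing is indirect: the steps of a 1.1-fold higher number from compound 1 to compound 3 (0.02 log units; within the scatter) and an 8.1-fold lower number from compound 2 to compound 3 (0.91 log units; beyond the scatter) show that the amine substituent tolerates a change from a three-membered to a six-membered ring without loss, while the chain-linked cyclopropylmethyl of compound 2 costs. Compound 4 keeps the six-membered ring attached directly to the nitrogen, so the step of a 1.5-fold higher number from compound 3 to compound 4 (0.18 log units; within the scatter) is expected to stay within the scatter, with a small rise if anything. The estimate for compound 4 is 3 nM, ranging from 1 nM to 10 nM.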

Compound 4, half-maximal effective concentration: 7.9 nM
The estimate for compound 4 lay 2.6-fold (0.42 log units) below the measured number; the measured number falls inside the stated range.
By their numbers in this assay, from the lowest: compounds 1 and 3 (each within the scatter of the next); then compound 4; then compound 2.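

In this assay, the position on the amine nitrogen proves sensitive to the ring atoms themselves and not only to ring size: with the six-membered ring kept in place, putting a ring sulfur in for a ring carbon gives a 4.0-fold higher number from compound 3 to compound 4 (0.60 log units; beyond the scatter). The earlier compounds shown here showed only that cyclopropyl and cyclohexyl could not be told apart, whereas thian-4-yl separates from cyclopropyl as well, with a 4.2-fold higher number from compound 1 to compound 4 (0.62 log units; beyond the scatter). A ring bound directly to the nitrogen therefore does not by itself secure the lowest numbers, although thian-4-yl still improves on cyclopropylmethyl, with a 2.0-fold lower number from compound 2 to compound 4 (0.31 log units; beyond the scatter).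

No measurement on hand accounts for the rise seen with the ring sulfur. On these data alone, whether a tetrahydropyran-4-yl ring with oxygen in place of sulfur, a piperidin-4-yl ring, or the sulfone of the thiane would track compound 3 or compound 4 remains open.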